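This account rests on a few compounds, and the source may have more. Where it says the series, first, only, none or still open, it means among the compounds named here.

Measured in an ADME assay on liver for metabolic stability, with Liver microsome (Homo sapiens) as the target, read by LC-MS, using microsomes; on this read-out lower numbers stand for slow clearance and higher numbers for fast clearance:
- Compound 1 `CC(C)(C)[C@@H](O)C(=O)N1C[C@@H]2C[C@@H]2[C@H]1C(=O)NCc1cc(Cl)ccc1-n1cnnn1`: < 15 mL.min-1.g-1, a limit of the assay
- Compound 2 `O=C(NCc1cc(Cl)ccc1-n1cnnn1)[C@@H]1[C@H]2C[C@H]2CN1C(=O)[C@H](O)C1CCCCC1`: 110 mL.min-1.g-1
- Compound 3 `CC(C)(C)OC[C@@H](O)C(=O)N1C[C@@H]2C[C@@H]2[C@H]1C(=O)NCc1cc(Cl)ccc1-n1cnnn1`: 37 mL.min-1.g-1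

Compound 1 gave only a limit, so just two of these results are actual numbers. Of those two, compound 3 has the lower, with a 3.0-fold lower number from compound 2 to compound 3 (0.47 log units; beyond the scatter).

Compound 4 `O=C(NCc1cc(Cl)ccc1-n1cnnn1)[C@@H]1[C@H]2C[C@H]2CN1C(=O)[C@H](O)CC1CC1` has not yet been measured. It carries cyclopropyl in place of tert-butoxy on a saturated chain carbon, two bonds along the chain from a carbonyl carbon and an oxygen on a saturated carbon. The same difference can be read as (tert-butoxy)methyl to cyclopropylmethyl.

The closest evidence comes from changes to this same side group: an at least 7.3-fold higher number from compound 1 to compound 2 (0.86 log units; beyond the scatter), an at least 2.4-fold higher number from compound 1 to compound 3 (0.39 log units; beyond the scatter) and a 3.0-fold lower number from compound 2 to compound 3 (0.47 log units; beyond the scatter). All three lie beyond the scatter, so this part of the molecule can shift the number, but none of them tests cyclopropylmethyl. They suggest a plausible size of change, not its direction. The expected step is a 1.1-fold higher number from compound 3 to compound 4 (0.03 log units; within the scatter), so no change beyond the scatter is expected. For compound 4 the estimated value is 40 mL.min-1.g-1, with an expected range of 18 mL.min-1.g-1 to 90 mL.min-1.g-1.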

Compound 4, intrinsic clearance in microsomes: < 14 mL.min-1.g-1
Compound 4 gave a limit, no number (the forecaster's own chance of this, stated with the estimate: 15%); at least 2.8-fold (0.45 log units) between middle value and limit.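

In this assay, compound 4 shows that a ring on this side chain need not bring a high number, as it did in compound 2: changing cyclohexyl to cyclopropylmethyl gives an at least 7.8-fold lower number from compound 2 to compound 4 (0.89 log units; beyond the scatter). Replacing tert-butoxy with cyclopropyl also lowers the number, with an at least 2.6-fold lower number from compound 3 to compound 4 (0.42 log units; beyond the scatter), so this change at the far end of the side chain moves the read-out beyond the scatter. Compound 1 and compound 4 each gave only a limit, and the step between them cannot be read.

The compounds shown leave open how far the true value of compound 4 lies from its limit and whether the result depends on the three-membered ring itself. A cyclobutylmethyl group or a plain butyl chain at this position would help to separate these possibilities.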